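The source may report more compounds than this note shows. Statements on the series, on what has been measured and on what is new or still open speak of the compounds shown alone.

Measured compounds:
Compound 1, `O=C(NCc1ccc(Cl)cc1Cl)[C@@H]1CCC(=O)N1c1ccsc1`, gives 813 nM in an assay on HEK293 cells for inhibition of P2X purinoceptor 7 (Homo sapiens), read by flow cytometry, with stated times of 15 min and 1 h; on this read-out lower numbers stand for stronger inhibition and higher numbers for weaker inhibition.
Compound 2, `O=C(NCc1ccc(Cl)cc1Cl)[C@@H]1CCC(=O)N1c1nccs1`, gives 415 nM in this assay.
Compound 3, `O=C(NCc1ccc(Cl)cc1Cl)[C@@H]1CCC(=O)N1c1cscn1`, gives 256 nM in this assay.

Compound 3 has the lowest number of the three. For the measured compounds named here, its gap to compound 2 lies within the scatter; the only step beyond the scatter here is a 3.2-fold lower number from compound 1 to compound 3 (0.50 log units; beyond the scatter), while a 2.0-fold lower number from compound 1 to compound 2 (0.29 log units; within the scatter) and a 1.6-fold lower number from compound 2 to compound 3 (0.21 log units; within the scatter) are not.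

Compound 4, `O=C(NCc1ccc(Cl)cc1Cl)[C@@H]1CCC(=O)N1Cc1ccccc1Cl`, differs from compound 3 in one place: 2-chlorobenzyl in place of 1,3-thiazol-4-yl on an amide-type nitrogen in a ring. Every measured step exchanges one five-membered heteroaromatic ring for another on this same nitrogen, so none bears directly on a benzyl group entering there. With no guidance, compound 4 is expected to stay near compound 3, with a 1.6-fold higher number from compound 3 to compound 4 (0.19 log units; within the scatter), and a wide range is estimated: 400 nM, between 100 nM and 2000 nM.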

Compound 4, half-maximal inhibitory concentration: 3460 nM
Compound 4: middle estimate off by 8.7-fold (0.94 log units), on the low side; the measured number lies above the stated range.
By their numbers in this assay, from the lowest: compounds 3, 2 and 1 (each within the scatter of the next, the first and the last beyond it); then compound 4.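

On the amide-type nitrogen in a ring, 2-chlorobenzyl is the first group shown that is not a five-membered aromatic ring, and in this assay it gives a 14-fold higher number from compound 3 to compound 4 (1.13 log units; beyond the scatter) and an 8.3-fold higher number from compound 2 to compound 4 (0.92 log units; beyond the scatter) as well as a 4.3-fold higher number from compound 1 to compound 4 (0.63 log units; beyond the scatter) as its steps. Each of these steps is larger than any step among the three earlier compounds, so this position tolerates the exchange of 2-chlorobenzyl for these rings poorly. Nothing available gives a reason for this rise.

Because 2-chlorobenzyl differs from these rings in several features at once, the compounds shown do not separate the contributions of its chlorine, its ring and its linking carbon. As far as these compounds go, whether a plain benzyl, phenyl or pyridinyl group on this nitrogen would lie nearer compound 3 or compound 4 remains open.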